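From Methyl to Fluoro on the Shared Core

The source may report more compounds than this note shows. Statements on the series, on what has been measured and on what is new or still open speak of the compounds shown alone.

Values in a physicochemical assay for pharmacokinetics, at pH 8; on this read-out higher numbers stand for a longer-lived compound and lower numbers for a shorter-lived compound:
Compound 1 `O=C(Sc1cccnc1C(=O)O)c1ccc(C(F)(F)F)cc1`: 10.1 h
Compound 2 `Cc1ccc(C(=O)Sc2cccnc2C(=O)O)cc1`: 80.1 h

Of the two measured compounds, compound 2 stands highest, and the gap down to compound 1 lies beyond the scatter. The compound now awaiting measurement is compound 3 `O=C(Sc1cccnc1C(=O)O)c1ccc(F)cc1`, which differs from compound 2 in one place: fluoro in place of methyl on an aromatic carbon, with fluoro in place of methyl on an aromatic carbon. Within the data shown here, only one measured step bears on this change, a modest one: a 7.9-fold higher number from compound 1 to compound 2 (0.90 log units; beyond the scatter). Among the measured compounds shown here, that step shows methyl with the higher number and trifluoromethyl with the lower, but no measured compound yet carries fluoro. A lower number than that of compound 2 is therefore expected, though the drop should be smaller than the whole of that step. The expected step is a 2.3-fold lower number from compound 2 to compound 3 (0.36 log units; beyond the scatter). The estimate for compound 3 is 35 h, with an expected range from 14 h to 85 h.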

Compound 3, half-life: 111 h
The estimate for compound 3 lay 3.2-fold (0.50 log units) below the measured number, and the stated range ends below it.
By their numbers in this assay, from the lowest: compound 1; then compounds 2 and 3 (each within the scatter of the next).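

In this assay the step of a 1.4-fold higher number from compound 2 to compound 3 (0.14 log units; within the scatter) stays inside the usual scatter, so at this place, on an aromatic carbon para to a large group, fluoro and methyl give numbers that cannot be told apart. The large step of an 11-fold higher number from compound 1 to compound 3 (1.04 log units; beyond the scatter) joins the earlier step away from trifluoromethyl, so among these three groups only trifluoromethyl sets its compound apart, leaving compound 1 at the low end. Nothing measured here explains this difference.

Going by these compounds, whether other groups at this place, such as chlorine, methoxy or nitrile, would join compound 1 or stay with compound 2 and compound 3 remains open. On these data alone, it is also open whether the same pattern would hold if the carboxylic acid on the shared core were an ester or an amide.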